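Two-ring aryloxypropyl ethers: an ortho-bromo replacement

The source may hold more compounds than are shown below. What is called first, only, known or untested is meant among the compounds shown, and "the series" means these compounds.

Measured compounds:
compound 1, `NC1=NC2(CCOCC2)N(OCCCOc2cccc(Cl)c2)C(N)=N1`, 1020 nM
compound 2, `Cc1ccc(OCCCON2C(N)=NC(N)=NC23CCOCC3)cc1`, "not determined" (no result reported)
compound 3, `NC1=NC2(CCOCC2)N(OCCCOc2ccc(Cl)cc2)C(N)=N1`, "not determined" (no result reported)

In a functional assay on MDA-MB-231 cells (Homo sapiens) for antiproliferative activity, read by MTT assay, with a stated time of 72 h (a higher number here means a weaker inhibitor, a lower number a stronger inhibitor), compound 1 gives 1020 nM. Compound 2 has no result in this assay, and compound 3 likewise has no result there: for it there is no number to stand on, and a second compound of the set is in the same position. For the measured compounds named here, no step between two measured compounds is available, so the only firm point in this assay is the value of compound 1.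

Compound 4, `NC1=NC2(CCOCC2)N(OCCCOc2ccccc2Br)C(N)=N1`, differs from compound 3 by 2-bromophenyl in place of 4-chlorophenyl on an oxygen on a saturated carbon. The oxygen on a saturated carbon carries the aryl group in both, and the core is the same. Because compound 3 has no value, the size of the step from it cannot be read from the data; the step is expected to be modest in this assay, with no direction that can be anchored, and it may well stay within the scatter. Compound 4 is therefore expected to sit near compound 1, with an estimated value of 1500 nM, and a range from 400 nM to 6000 nM.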

Compound 4, half-maximal inhibitory concentration: 910 nM
For compound 4 the middle estimate is 1.6-fold (0.22 log units) above the measured one; the measured number falls inside the stated range.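

In this assay, for the compounds shown here, the exchange of 3-chlorophenyl for 2-bromophenyl on an oxygen on a saturated carbon gives a 1.1-fold lower number from compound 1 to compound 4 (0.05 log units; within the scatter) and thus the first step that can be read at this place, and it shows that these two aryl groups cannot be told apart in this read-out. The place therefore accepts a change of both the halogen and its printed ring position without a step beyond the scatter, although this rests on a single pair of compounds and supports no wider pattern. Compound 2 and compound 3 have no result, so every step that touches them, including the one from 4-chlorophenyl to 2-bromophenyl, cannot be read, and no measurement offers an explanation for the close match between compound 1 and compound 4.

The compounds shown leave open whether any aryl group at this place would move the number beyond the scatter, as all the values in hand come from two halogenated phenyl groups. They also leave open how an amine or a carboxylic acid on the aryl group, or a longer chain between the two oxygens, would read in this assay on the shared core.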